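A few compounds are considered here, and "the series" means these few. Any claim that something is new, unique, unknown or untested is made for them only; others in the source may bear on it.

Measured so far in an assay (Rattus norvegicus) for inhibition of Fatty-acid amide hydrolase 1 (Homo sapiens); on this read-out higher numbers stand for weaker inhibition and lower numbers for stronger inhibition:
Compound 1, `Nc1ccccc1-c1cnc(C(=O)CCCCCCc2ccccc2)o1`, gives 750 nM.
Compound 2, `O=C(CCCCCCc1ccccc1)c1ncc(-c2ccc(O)cc2)o1`, gives 140 nM.
Compound 3, `Cc1cccnc1-c1cnc(C(=O)CCCCCCc2ccccc2)o1`, gives 15 nM.

Compound 3 holds the lowest number of the three in this assay. Its lead over compound 2 is a 9.3-fold lower number from compound 2 to compound 3 (0.97 log units; beyond the scatter), and over compound 1 it is a 50-fold lower number from compound 1 to compound 3 (1.70 log units; beyond the scatter); both steps lie beyond the scatter, so compound 3 is the strongest inhibitor of the three. The step of a 5.4-fold lower number from compound 1 to compound 2 (0.73 log units; beyond the scatter) shows that the group on this position of the shared core moves the read-out by itself.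

Compound 4, `Cc1ccc(-c2cnc(C(=O)CCCCCCc3ccccc3)o2)nc1`, keeps every atom of compound 3 and changes only the position of the methyl on the pyridyl ring: 5-methylpyridin-2-yl in place of 3-methylpyridin-2-yl on an aromatic carbon. Going by the values given here, none of the measured steps covers such a move of a methyl within the same ring; each of them swaps the whole aromatic group. The two steps ending at compound 3 only show that the 3-methylpyridin-2-yl group is well tolerated, and they give no guide to a shift of the methyl. Among the compounds with values here, with no direct precedent, a small or modest step is expected, more likely toward a higher number than a lower one, since compound 3 already sits at the favourable end of the set.

Compound 4 is therefore estimated at 30 nM in this assay, within 8 nM to 120 nM, meaning an expected step of a 2.0-fold higher number from compound 3 to compound 4 (0.30 log units; within the scatter).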

Compound 4, inhibition constant: 2.8 nM
Compound 4: the middle estimate sits 11-fold (1.03 log units) above what was measured; measured number below the stated range.
By their numbers in this assay, from the lowest: compound 4; then compound 3; then compound 2; then compound 1.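

In this assay, moving the methyl within the same ring, with the counted heavy atoms, donors and acceptors unchanged, is enough on its own to give a 5.4-fold lower number from compound 3 to compound 4 (0.73 log units; beyond the scatter), so where the methyl sits on the pyridyl ring matters as well as which aromatic group occupies this place on the shared core, something the earlier swaps of whole groups could not separate. The 5-methylpyridin-2-yl group also widens the range at this place, with a 50-fold lower number from compound 2 to compound 4 (1.70 log units; beyond the scatter) and a 270-fold lower number from compound 1 to compound 4 (2.43 log units; beyond the scatter), and since all three steps lie beyond the scatter, compound 4 is the strongest inhibitor of the four. Nothing available explains why this shift of the methyl has such an effect.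

The compounds shown leave open what the methyl itself contributes, since they include neither an unsubstituted pyridin-2-yl group nor a 5-chloropyridin-2-yl or 5-methoxypyridin-2-yl group for comparison. They also leave open how a carboxylic acid on the pyridyl ring, or a shorter chain on the carbonyl, would behave alongside the 5-methylpyridin-2-yl group.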